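A few compounds are considered here, and "the series" means these few. Any claim that something is new, unique, unknown or untested is made for them only; others in the source may bear on it.

Of the compounds shown here, three that share one core have been tested so far, and they differ only in the aryl group attached to an aromatic nitrogen. Compound 1 `CC(=O)Nc1ccc(-n2nncc2CN2C(=O)C3(C(C#N)=C(N)Oc4c(N)cc5nc6ccccc6nc5c43)c3ccccc32)cc1` carries a 4-acetamidophenyl group at that position. In a functional assay on MCF7 cells (Homo sapiens) for antiproliferative activity, read by MTT assay, with a stated time of 48 h (on this read-out higher numbers stand for weaker inhibition and lower numbers for stronger inhibition), compound 1 gives > 50000 nM, which is a limit of the assay and not a number. Compound 2 `Cc1ccc(-n2nncc2CN2C(=O)C3(C(C#N)=C(N)Oc4c(N)cc5nc6ccccc6nc5c43)c3ccccc32)cc1C` carries a 3,4-dimethylphenyl group instead. In this assay compound 2 gives > 50000 nM, again a limit rather than a number. Compound 3 `Cc1ccc(C)c(-n2nncc2CN2C(=O)C3(C(C#N)=C(N)Oc4c(N)cc5nc6ccccc6nc5c43)c3ccccc32)c1` carries a 2,5-dimethylphenyl group. In this assay compound 3 gives > 50000 nM, also a limit. Compound 3 therefore stands at the same limit as the other two, and no order among them can be read.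

For the same reason the steps between the measured compounds stay unreadable: a step that the two limits leave unreadable from compound 1 to compound 2, a step that the two limits leave unreadable from compound 1 to compound 3 and a step that the two limits leave unreadable from compound 2 to compound 3. The reason is plain: the limit of > 50000 nM in this assay, at which 3 of the 3 values shown sit.

Compound 4 `Cc1ccc(Cl)cc1-n1nncc1CN1C(=O)C2(C(C#N)=C(N)Oc3c(N)cc4nc5ccccc5nc4c32)c2ccccc21` is not yet measured. It differs from compound 3 in one place: chloro in place of methyl on an aromatic carbon. Among the measured compounds shown here, no measured step gives a readable size or direction, so there is nothing to lean on, and the step from compound 3 to compound 4 is expected to be a number no higher from compound 3 to compound 4 (the limit leaves the size open). Compound 4 is estimated at 50000 nM, with a range from 10000 nM to 200000 nM, most likely reported once more as a limit.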

Compound 4, half-maximal inhibitory concentration: 43500 nM
Beside the measured number, compound 4's estimate is 1.1-fold (0.06 log units) above it; the measured number falls inside the stated range.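

In this assay, among the compounds shown here, compound 4 gives 43500 nM, the first value that is a number and not a limit, so this aryl position can now give a measurable read-out. Chloro in place of methyl, para to a methyl group, gives an at least 1.1-fold lower number from compound 3 to compound 4 (0.06 log units; that floor lies within the scatter), while the changes of the whole aryl group give an at least 1.1-fold lower number from compound 2 to compound 4 (0.06 log units; that floor lies within the scatter) and an at least 1.1-fold lower number from compound 1 to compound 4 (0.06 log units; that floor lies within the scatter). All three are floors and not true sizes, and none shows a change beyond the usual scatter, because the other three compounds give no number to compare with: the limit of > 50000 nM in this assay, at which 3 of the 4 values shown sit.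

On these data alone, the true size of each step therefore remains open, as do the steps among compound 1, compound 2 and compound 3, which cannot be read. Also open, as far as these compounds go, is whether fluoro, bromo, methoxy or an amine on the same ring carbon would give a clearly lower number than chloro, and whether the methyl group para to that carbon is needed for compound 4 to give a number at all.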